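A few compounds are considered here, and "the series" means these few. Any claim that something is new, unique, unknown or untested is made for them only; others in the source may bear on it.

Four quinoxaline-type sulfones with an anilino substituent are compared in a functional assay on A549 cells (Homo sapiens) for cytotoxicity, read by MTT assay, with a stated time of 72 h; a lower number here means a stronger inhibitor, a higher number a weaker inhibitor. Compound 1 `O=S(=O)(c1ccccc1)c1nc2ccccc2nc1Nc1ccc(F)cc1` reaches only a limit in this assay, reported as > 50000 nM. Compound 2 `O=S(=O)(c1ccccc1)c1nc2ccccc2nc1Nc1ccc(Cl)cc1` gives 30700 nM in this assay, and compound 3 `Cc1ccc(S(=O)(=O)c2nc3ccccc3nc2Nc2ccc(F)cc2)cc1` gives 39200 nM in this assay. The change from compound 1 to compound 2 is chloro in place of fluoro on an aromatic carbon, and its step is an at least 1.6-fold lower number from compound 1 to compound 2 (0.21 log units; that floor lies within the scatter), a floor set by the fact that (the limit of > 50000 nM in this assay, at which 1 of the 3 values shown sits). The cores of compound 1 and compound 3 differ by methyl in place of hydrogen on an aromatic carbon, with a step of an at least 1.2-fold lower number from compound 1 to compound 3 (0.10 log units; that floor lies within the scatter). Compound 4 `Cc1ccc(S(=O)(=O)c2nc3ccccc3nc2Nc2ccc(Cl)cc2)cc1` is not yet measured in this assay. It differs from compound 3 by chloro in place of fluoro on an aromatic carbon, the same change that was made from compound 1 to compound 2, at a place described in the same words. The step from compound 3 to compound 4 is expected to be a 1.6-fold lower number from compound 3 to compound 4 (0.20 log units; within the scatter), resting on the step from compound 1 to compound 2 of an at least 1.6-fold lower number from compound 1 to compound 2 (0.21 log units; that floor lies within the scatter) and on the value of compound 3 of 39200 nM. Compound 4 is therefore estimated at 25000 nM in this assay, between 12000 nM and 50000 nM.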

Compound 4, half-maximal inhibitory concentration: 54200 nM
The estimate for compound 4 lay 2.2-fold (0.34 log units) below the measured number; measured number outside the range, above it.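

In this assay, the new steps are a 1.4-fold higher number from compound 3 to compound 4 (0.14 log units; within the scatter) for chloro in place of fluoro and a 1.8-fold higher number from compound 2 to compound 4 (0.25 log units; within the scatter) for methyl in place of hydrogen. Set beside its earlier step, the chloro change reads as follows: the same change on two cores in this assay, an at least 1.6-fold lower number (0.21 log units; that floor lies within the scatter) from compound 1 to compound 2 and a 1.4-fold higher number (0.14 log units; within the scatter) from compound 3 to compound 4; the limit leaves it open whether they differ. The methyl change reads the same way, so these compounds show neither that a change carries over from one core to the other nor that it fails to: the same change on two cores in this assay, an at least 1.2-fold lower number (0.10 log units; that floor lies within the scatter) from compound 1 to compound 3 and a 1.8-fold higher number (0.25 log units; within the scatter) from compound 2 to compound 4; the limit leaves it open whether they differ.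

Compound 1 stands at a limit and not at a number, and this keeps both comparisons open: the limit of > 50000 nM in this assay, at which 1 of the 4 values shown sits. On these data alone, it also remains open whether a methoxy group, a nitrile, an amine or a carboxylic acid at these places would give a step beyond the scatter, and whether either change would behave alike on a further core.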